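The source may report more compounds than this note shows. Statements on the series, on what has been measured and on what is new or still open speak of the compounds shown alone.

The measured compounds in a functional assay on Jurkat cells (Homo sapiens) for antiproliferative activity, read by MTT assay and trypan blue exclusion, with a stated time of 72 h (a lower number here means a stronger inhibitor, a higher number a weaker inhibitor), are these.
Compound 1, `COC(=O)c1ccc(C2SCC(=O)N2c2ccc(N3CCN(Cc4cccc(C)c4)CC3)cn2)c(OC)c1`, gives > 100000 nM, which is a limit of the assay rather than a number.
Compound 2, `COC(=O)c1ccc(C2SCC(=O)N2c2ccc(N3CCN(S(=O)(=O)c4ccc(F)cc4)CC3)cn2)c(OC)c1`, gives 78300 nM.
Compound 3, `COC(=O)c1ccc(C2SCC(=O)N2c2ccc(N3CCN(S(=O)(=O)c4cc(Cl)ccc4Cl)CC3)cn2)c(OC)c1`, gives > 100000 nM, again a limit of the assay rather than a number.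

Compound 3 therefore stands at the edge of what this assay can report, as the limit of > 100000 nM in this assay, at which 2 of the 3 values shown sit, shows. The measured steps give little to hold on to: the step of an at least 1.2-fold lower number from compound 1 to compound 2 (0.10 log units; that floor lies within the scatter) and the step of an at least 1.2-fold higher number from compound 2 to compound 3 (0.10 log units; that floor lies within the scatter) both stay inside the scatter once their floor is taken into account, and the step that the two limits leave unreadable from compound 1 to compound 3 cannot be read at all, because both ends are limits.

The next compound, compound 4, is `COC(=O)c1ccc(C2SCC(=O)N2c2ccc(N3CCN(S(=O)(=O)c4c(C)cc(C)cc4C)CC3)cn2)c(OC)c1`. The change from compound 3 is 2,4,6-trimethylphenyl in place of 2,5-dichlorophenyl on a sulfonyl sulfur. Within the data shown here, of the measured steps, only the one from compound 2 to compound 3 alters the group on the sulfonyl sulfur, and it moved nothing readable beyond the scatter. The step from compound 3 to compound 4 is therefore expected to be a number no higher from compound 3 to compound 4 (the limit leaves the size open), that is, none that the scatter would not cover.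

Compound 4 is estimated at 100000 nM, with a range from 50000 nM to 250000 nM, and it is expected that the assay may again report only a limit.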

Compound 4, half-maximal inhibitory concentration: > 100000 nM
Compound 4 ended at the assay's limit; the forecaster's own chance of this, stated with the estimate: 65%; the middle value lies on the limit itself.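

In this assay, 2,4,6-trimethylphenyl is a third group tried on the sulfonyl sulfur, after 4-fluorophenyl and 2,5-dichlorophenyl. Compound 4 gives > 100000 nM, which is a limit of the assay and not a number. The one readable step, an at least 1.2-fold higher number from compound 2 to compound 4 (0.10 log units; that floor lies within the scatter), sets no order between these two groups, and the steps to compound 4 from compound 1 and compound 3 cannot be read, with a limit at both ends of each; what the change does show is that three methyl groups on this ring bring no measurable value and that the series gathers further at one edge of the assay: the limit of > 100000 nM in this assay, at which 3 of the 4 values shown sit.

On these data alone, how far compound 1, compound 3 and compound 4 lie past that limit stays unknown, so they cannot be ranked against one another. As far as these compounds go, it also stays open whether a different group on this sulfur, such as a plain methyl or a phenyl ring carrying an amine or a carboxylic acid, would give a value well inside the range of the assay.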